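The source may hold more compounds than are shown below. What is called first, only, known or untested is meant among the compounds shown, and "the series" means these compounds.

Compound 1 `COc1cc(C(=O)c2cn(-c3ccccc3)cc2-c2ccc(N)cc2)cc(OC)c1OC`: 9 nM
Compound 2 `COc1cc(C(=O)c2cn(-c3ccccc3)cc2-c2ccccc2Cl)cc(OC)c1OC`: 76 nM
Compound 3 `COc1cc(C(=O)c2cn(-c3ccccc3)cc2-c2cccc(Cl)c2)cc(OC)c1OC`: 540 nM

These values come from a functional assay on MCF7 cells (Homo sapiens) for cytotoxicity, read by MTT assay, with a stated time of 96 h; on this read-out lower numbers stand for stronger inhibition and higher numbers for weaker inhibition. Compound 3 stands at the weak end of the set, with the highest number, and both other compounds lie beyond the scatter from it. Compound 4 `COc1cc(C(=O)c2cn(-c3ccccc3)cc2-c2ccc(Cl)cc2)cc(OC)c1OC` has not yet been measured. It carries 4-chlorophenyl in place of 3-chlorophenyl on an aromatic carbon of a five-membered aromatic ring with 1 nitrogen: 4-chlorophenyl in place of 3-chlorophenyl on an aromatic carbon.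

Among the compounds with values here, three measured steps bear on this change. The closest is the one between the two chlorophenyl compounds, a 7.1-fold higher number from compound 2 to compound 3 (0.85 log units; beyond the scatter), which shows that exchanging one chlorophenyl group for another can shift the number modestly. Compound 1, with its 4-aminophenyl group, has the lowest number, and the steps away from it are an 8.4-fold higher number from compound 1 to compound 2 (0.93 log units; beyond the scatter) and a 60-fold higher number from compound 1 to compound 3 (1.78 log units; beyond the scatter). Within the data shown here, no measured compound carries 4-chlorophenyl, so the data cannot separate the effect of the amino group from that of its place on the ring, and the expectation remains loose. A modest move toward a lower number is expected in this assay, and the expected step is a 4.5-fold lower number from compound 3 to compound 4 (0.65 log units; beyond the scatter). For compound 4 the estimated value is 120 nM, with an expected range from 25 nM to 550 nM.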

Compound 4, half-maximal inhibitory concentration: 290 nM
For compound 4 the middle estimate is 2.4-fold (0.38 log units) below the measured one; measured number inside the range.
By their numbers in this assay, from the lowest: compound 1; then compound 2; then compounds 4 and 3 (each within the scatter of the next).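

In this assay, moving the chlorine from 3-chlorophenyl to 4-chlorophenyl gives a step that does not separate the two groups (a 1.9-fold lower number from compound 3 to compound 4 (0.27 log units; within the scatter)), whereas 2-chlorophenyl stands apart from 4-chlorophenyl as well as from 3-chlorophenyl (a 3.8-fold higher number from compound 2 to compound 4 (0.58 log units; beyond the scatter); a 7.1-fold higher number from compound 2 to compound 3 (0.85 log units; beyond the scatter)). Within the data shown here, compound 4 also gives the first comparison in which only chloro and amino are exchanged at the same place on the phenyl ring, and this step is large (a 32-fold higher number from compound 1 to compound 4 (1.51 log units; beyond the scatter)), so the distance of compound 1 from the chlorophenyl compounds no longer rests only on pairs that differ in both the group and its place on that ring. Nothing given here accounts for these differences.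

The compounds shown leave open whether 2-aminophenyl or 3-aminophenyl would follow the order seen among the three chlorophenyl compounds. They also leave open whether the low number of compound 1 is particular to the amine or would also be found with 4-hydroxyphenyl or 4-methoxyphenyl on the same aromatic carbon.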